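Swapping cyclopropyl for isopropyl on a NOTUM inhibitor

The source may hold more compounds than are shown below. What is called first, only, known or untested is meant among the compounds shown, and "the series" means these compounds.

Measured so far:
- compound 1, `Cc1cc(C(=O)O)c(C)n1CC1CC1`: 12700 nM
- compound 2, `Cc1cc(C(=O)O)c(C)n1-c1cccc(C2CC2)c1`: 580 nM

Both compounds share the same acid-bearing core and differ only in the group attached to its nitrogen. In an assay on cells for inhibition of Palmitoleoyl-protein carboxylesterase NOTUM variant C330S (Homo sapiens), read by fluorescence, with a stated time of 40 min (on this read-out higher numbers stand for weaker inhibition and lower numbers for stronger inhibition), compound 1 gives 12700 nM, whereas compound 2 gives 580 nM. Compound 2 therefore holds the lower of the two numbers, and since the gap to compound 1 lies well beyond the usual scatter, compound 2 is the stronger inhibitor of the pair.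

Compound 3, `Cc1cc(C(=O)O)c(C)n1-c1cccc(C(C)C)c1`, keeps the aryl ring of compound 2 and changes only the small group on it: isopropyl in place of cyclopropyl on an aromatic carbon. The entering group has the same number of carbon atoms as the one that leaves, and neither carries a donor or an acceptor. Among the compounds with values here, no measured pair here shows what such a swap does, so the expectation rests on the closeness of the two groups in size and composition. The step from compound 2 to compound 3 is expected to be a 1.6-fold higher number from compound 2 to compound 3 (0.19 log units; within the scatter), a modest shift that may well stay within the scatter. Compound 3 is therefore estimated at 900 nM, with a range from 300 nM to 2700 nM.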

Compound 3, half-maximal inhibitory concentration: 360 nM
For compound 3 the middle estimate is 2.5-fold (0.40 log units) above the measured one; low and high end bracket the measured number.
By their numbers in this assay, from the lowest: compounds 3 and 2 (each within the scatter of the next); then compound 1.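

In this assay, putting isopropyl in place of cyclopropyl on an aromatic carbon, meta to a large group, gives a 1.6-fold lower number from compound 2 to compound 3 (0.21 log units; within the scatter), a step within the scatter, so compound 2 and compound 3 cannot be told apart on this read-out. Within the data shown here, this is the first look at the small group on the aryl ring, since the earlier comparison covered only the whole group on the nitrogen of the shared core, and it shows that, for this pair, the three-membered ring of cyclopropyl is not needed to stay in the same range of numbers: the open-chain isopropyl, with the same count of heavy atoms, does as well. Nothing available here explains why the two groups are so closely matched in this assay.

Going by these compounds, the two groups compared at this position are both small and made of carbon alone, so it remains open how the number would respond to a larger tert-butyl group, or to a group containing other atoms, such as methoxy or an amine. On these data alone, it also remains open whether a plain hydrogen at this position would stay in the same range as compound 2 and compound 3.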